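This account rests on a few compounds, and the source may have more. Where it says the series, first, only, none or still open, it means among the compounds named here.

Compound 3, `CC(=O)OC[C@H]1O[C@H](OC[C@@H](Cn2cc(CN(c3nc(-c4ccc(Br)cc4)no3)C3CCCCC3)nn2)OC(C)=O)C=C[C@@H]1OC(C)=O`, gives 39.1 ug/mL in an ADME assay on RAW264.7 cells (Mus musculus) for cytotoxicity, read by MTT assay, with a stated time of 48 h; on this read-out higher numbers stand for lower toxicity in this test and lower numbers for higher toxicity in this test. On the bare numbers compound 3 sits between its two neighbours, though neither gap reaches beyond the scatter: compound 2, `CC(=O)OC[C@H]1O[C@H](OC[C@@H](Cn2cc(CN(c3nc(-c4ccc(C)cc4)no3)C3CCCCC3)nn2)OC(C)=O)C=C[C@@H]1OC(C)=O`, gives 45.3 ug/mL in this assay, and compound 1, `CC(=O)OC[C@H]1O[C@H](OC[C@@H](Cn2cc(CN(c3nc(-c4ccccc4)no3)C3CCCCC3)nn2)OC(C)=O)C=C[C@@H]1OC(C)=O`, gives 28.6 ug/mL. The steps among these three are a 1.6-fold higher number from compound 1 to compound 2 (0.20 log units; within the scatter), a 1.4-fold higher number from compound 1 to compound 3 (0.14 log units; within the scatter) and a 1.2-fold lower number from compound 2 to compound 3 (0.06 log units; within the scatter), each of them within the scatter.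

Compound 4, `COc1ccc(-c2noc(N(Cc3cn(C[C@H](CO[C@@H]4C=C[C@H](OC(C)=O)[C@@H](COC(C)=O)O4)OC(C)=O)nn3)C3CCCCC3)n2)cc1`, differs from compound 3 by methoxy in place of bromo on an aromatic carbon. Within the data shown here, no measured step introduces a methoxy group, so the only guidance is that every change seen so far at this aromatic carbon, whether methyl or bromo in place of hydrogen or bromo in place of methyl, has left this assay unmoved beyond the scatter. On that basis the step of a 1.0-fold lower number from compound 3 to compound 4 (0.01 log units; within the scatter) is expected to stay within the scatter, with no direction claimed. Compound 4 is therefore estimated at 38 ug/mL in this assay, with a range from 20 ug/mL to 70 ug/mL.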

Compound 4, half-maximal cytotoxic concentration: 86.3 ug/mL
Beside the measured number, compound 4's estimate is 2.3-fold (0.36 log units) below it, outside the stated range (above it).
By their numbers in this assay, from the lowest: compounds 1, 3, 2 and 4 (each within the scatter of the next, the first and the last beyond it).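

At this position, on an aromatic carbon para to a large group, the earlier changes had left this assay unmoved beyond the scatter, but methoxy moves it, with (a 2.2-fold higher number from compound 3 to compound 4 (0.34 log units; beyond the scatter)) from the bromo compound and (a 3.0-fold higher number from compound 1 to compound 4 (0.48 log units; beyond the scatter)) from the unsubstituted one. Against methyl the same change gives (a 1.9-fold higher number from compound 2 to compound 4 (0.28 log units; within the scatter)), so the result sets methoxy apart from hydrogen and bromo but not from methyl. Nothing available explains this difference.

As far as these compounds go, it remains open whether a hydroxyl, an amine or a longer ether such as ethoxy at this carbon would behave like methoxy. From the compounds shown here alone, it is equally open whether the step from bromo to methoxy would hold if the rest of the shared core were changed.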